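Trimming the naphthalene of compound 3 down to a phenyl

The source may report more compounds than this note shows. Statements on the series, on what has been measured and on what is new or still open speak of the compounds shown alone.

Compound 3 `CC1CCN(C2CCN(S(=O)(=O)c3cccc(-c4ccc5ccccc5c4)c3)CC2)CC1` is the strongest of the three measured compounds in a functional assay on DLD-1 cells (Homo sapiens) for antiproliferative activity, read by CellTiter-Glo, with a stated time of 72 h (a higher number here means a weaker inhibitor, a lower number a stronger inhibitor), where compound 3 gives 2 nM. Compound 1 `CC1CCN(C2CCN(S(=O)(=O)c3cccc(-c4ccc(Cl)cc4)c3)CC2)CC1` gives 15 nM and compound 2 `COc1ccc(-c2cccc(S(=O)(=O)N3CCC(N4CCC(C)CC4)CC3)c2)cc1` gives 23 nM, both clearly weaker. Compound 4 `CC1CCN(C2CCN(S(=O)(=O)c3cccc(-c4ccccc4)c3)CC2)CC1` differs from compound 3 in one place: phenyl in place of naphthalen-2-yl on an aromatic carbon. Going by the values given here, the steps that bear on this are a 7.5-fold lower number from compound 1 to compound 3 (0.88 log units; beyond the scatter) and a 12-fold lower number from compound 2 to compound 3 (1.06 log units; beyond the scatter), which show how much the larger two-ring group gains over a single substituted ring. Removing the fused ring entirely, and leaving the phenyl without any substituent, is therefore expected to weaken inhibition beyond the scatter, so that compound 4 is expected to show a step of a 20-fold higher number from compound 3 to compound 4 (1.30 log units; beyond the scatter). Compound 4 is estimated at 40 nM, with a likely range from 12 nM to 130 nM.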

Compound 4, half-maximal inhibitory concentration: 2 nM
The estimate for compound 4 lay 20-fold (1.30 log units) above the measured number, outside the stated range (below it).
By their numbers in this assay, from the lowest: compounds 3 and 4 (each within the scatter of the next); then compounds 1 and 2 (each within the scatter of the next).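

In this assay the second fused ring can go with no change at the digits printed from compound 3 to compound 4 (within the scatter) and so the strength of compound 3 does not depend on the naphthalen-2-yl group. The plain phenyl is what separates from the substituted rings: hydrogen in place of methoxy gives a 12-fold lower number from compound 2 to compound 4 (1.06 log units; beyond the scatter) and hydrogen in place of chloro gives a 7.5-fold lower number from compound 1 to compound 4 (0.88 log units; beyond the scatter) and so among these compounds a substituent on the phenyl raises the number while the fused ring does not.

On these data alone, whether a smaller fluoro or an amine on that phenyl would also raise the number remains open. Nothing available explains this pattern.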